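The compounds below may be only part of what the source reports. "The series", "measured", "known", "first", "only" and "open" are said of these compounds alone.

Measured compounds:
compound 1, `CN(C)/N=N/c1ccccc1C(=O)/N=N/C(=O)CC#N`, in a functional assay on L1210 cells (Mus musculus) for antiproliferative activity (a higher number here means a more potent compound, by a factor of ten per unit of this negative logarithm, a lower number a less potent compound), compound 1 gives 2.63;
compound 2, `CN(C)/N=N/c1ccccc1C(N)=O`, in this assay compound 2 gives 3.31.

Compound 2 stands highest of the two numbers in this assay; its nearest neighbour is compound 1, which lies lower by a margin beyond the usual scatter. Compound 3, `CC(=O)/N=N/C(=O)c1ccccc1/N=N/N(C)C`, has not yet been measured. It differs from compound 2 in one place: a group of 5 heavy atoms (2 carbon, 2 nitrogen, 1 oxygen; no ring) in place of one nitrogen atom, on a carbonyl carbon. Going by the values given here, no step between measured compounds matches this change, so the expectation rests on what compound 1 and compound 2 show: compound 1, which also carries an extended chain on that carbonyl carbon, gives 2.63, below compound 2. Compound 3 is therefore expected to lose potency, with an estimated step of a number 0.51 log units lower from compound 2 to compound 3 (beyond the scatter). For compound 3 the estimate in this assay is 2.8, within a range from 2.3 to 3.4.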

Compound 3, logarithm of the reciprocal of the active concentration, log(1/C) in the L1210 assay: 3.05
For compound 3 the middle estimate is 0.25 log units below the measured one; low and high end bracket the measured number.
By their numbers in the L1210 assay, from the lowest: compound 1; then compounds 3 and 2 (each within the scatter of the next).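

In the L1210 assay the larger group on the carbonyl carbon, in place of the amino group, gives a number 0.26 log units lower from compound 2 to compound 3 (within the scatter), so this exchange on its own shows no loss of potency that can be told from scatter. The cyano group on the saturated chain carbon now has a step of its own: with hydrogen in its place there is a number 0.42 log units higher from compound 1 to compound 3 (beyond the scatter), a modest change. In a physicochemical assay for lipophilicity (a lower number here means a more polar compound, a higher number a more lipophilic compound), compound 2 gives 1.73 and compound 3 gives 1.49, values within the scatter of each other, and nothing available accounts for any of these steps.

Going by these compounds, what a carboxylic acid or a methyl ester on that carbonyl carbon would give in the L1210 assay stays open. So does the effect of a hydroxyl or an amine on the saturated chain carbon.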